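Methyl-to-fluoro swap on an imidazopyridine oxime series

The source may report more compounds than this note shows. Statements on the series, on what has been measured and on what is new or still open speak of the compounds shown alone.

Of the compounds shown here, three sharing a related core have been measured in a functional assay on the whole organism (strain NMRI) with Mus musculus as the target, with a stated time of 4 h; on this read-out lower numbers stand for an effect already at smaller amounts and higher numbers for an effect only at larger amounts of compound. Compound 1, `Cc1ccc(-c2nc3ccc(Br)cn3c2/C=N/O)cc1`, gives 20 mg/kg. Compound 2, `COc1ccc(Cn2cc(CO/N=C/c3c(-c4ccc(C)cc4)nc4c(C)cccn34)nn2)cc1`, gives 100 mg/kg, and compound 3, `COc1ccc(Cn2cc(CO/N=C/c3c(-c4ccc(F)cc4)nc4c(C)cccn34)nn2)cc1`, gives 40 mg/kg. Compound 1 stands at the lowest of the three numbers; its gap to compound 3 lies within the scatter, while its gap to compound 2 lies beyond it. Compound 2 and compound 3 differ in one place, (fluoro in place of methyl on an aromatic carbon), and the step is a 2.5-fold lower number from compound 2 to compound 3 (0.40 log units; beyond the scatter). How the core of compound 1 differs from that of compound 2 is not broken down here.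

Compound 4, `O/N=C/c1c(-c2ccc(F)cc2)nc2ccc(Br)cn12`, has not yet been measured. It differs from compound 1 by fluoro in place of methyl on an aromatic carbon, the same change as that between compound 2 and compound 3. On the strength of that earlier step, compound 4 is expected to show a 2.0-fold lower number from compound 1 to compound 4 (0.30 log units; within the scatter) in this assay, a modest lowering. The estimate for compound 4 is 10 mg/kg, with a range from 4 mg/kg to 25 mg/kg.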

Compound 4, minimum effective dose: 40 mg/kg
Compound 4: the middle estimate sits 4.0-fold (0.60 log units) below what was measured, and the stated range ends below it.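

In this assay, fluoro in place of methyl on an aromatic carbon gives a 2.0-fold higher number from compound 1 to compound 4 (0.30 log units; within the scatter), so on the core of compound 1 the swap has no effect that can be told from the scatter. The lowering seen on the other core did not carry over, and the two steps differ by more than the scatter of two such steps allows: the same change on two cores in this assay, a 2.5-fold lower number (0.40 log units; beyond the scatter) from compound 2 to compound 3 and a 2.0-fold higher number (0.30 log units; within the scatter) from compound 1 to compound 4, 5.0-fold (0.70 log units) apart, beyond the scatter of two such steps. The step on one core is thus no safe guide to the step on the other in this series, but with a single pair on each core this does not show which feature of the cores sets the two steps apart, nor whether the step on the core of compound 1 has any real direction.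

The compounds shown leave open whether other groups at the same place, such as chloro, a nitrile or an amine, would also separate the two cores. They also leave open how the swap would behave on any third core.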